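Aryl amide variation on a flavonol scaffold against HepG2 cells

A few compounds are considered here, and "the series" means these few. Any claim that something is new, unique, unknown or untested is made for them only; others in the source may bear on it.

Measured so far:
- compound 1 `O=C(Nc1cccc(-c2oc3cc(-c4ccc(F)cc4)ccc3c(=O)c2O)c1)c1ccc(F)cc1F`: 26400 nM
- compound 2 `COc1ccc(C(=O)Nc2cccc(-c3oc4cc(-c5ccc(F)cc5)ccc4c(=O)c3O)c2)c(F)c1`: 45300 nM
- compound 3 `Cc1cc(C)cc(C(=O)Nc2cccc(-c3oc4cc(-c5ccc(F)cc5)ccc4c(=O)c3O)c2)c1`: 13400 nM

These three compounds share one core and differ only in the aryl group attached to the amide carbonyl. In a functional assay on HepG2 cells (Homo sapiens) for antiproliferative activity, read by CCK-8 assay, with a stated time of 72 h (on this read-out lower numbers stand for stronger inhibition and higher numbers for weaker inhibition), compound 3 gives the lowest of the three numbers. Its nearest neighbour is compound 1, with a 2.0-fold lower number from compound 1 to compound 3 (0.29 log units; within the scatter), a gap that stays within the scatter; the gap to compound 2, a 3.4-fold lower number from compound 2 to compound 3 (0.53 log units; beyond the scatter), is the only one of the three that goes beyond it. The remaining pair shows a 1.7-fold higher number from compound 1 to compound 2 (0.23 log units; within the scatter).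

Compound 4 `O=C(Nc1cccc(-c2oc3cc(-c4ccc(F)cc4)ccc3c(=O)c2O)c1)c1cnc(Cl)nc1Cl` continues this series with 2,4-dichloropyrimidin-5-yl in place of 3,5-dimethylphenyl on a carbonyl carbon. Among the compounds with values here, the steps that bear on it are the two aryl exchanges at the same carbonyl carbon, from compound 1 to compound 3 and from compound 2 to compound 3, both of which moved the number only modestly. None of them introduces a heteroaromatic ring, so the bearing is indirect. The account therefore expects compound 4 to sit near the other aryl amides rather than well apart from them, with a step from compound 3 estimated at a 1.9-fold higher number from compound 3 to compound 4 (0.27 log units; within the scatter). The expected number for compound 4 in this assay is 25000 nM, with an estimated range from 8000 nM to 80000 nM.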

Compound 4, half-maximal inhibitory concentration: > 100000 nM
Compound 4 ended at the assay's limit; the forecaster's own chance of this, stated with the estimate: 15%; at least 4.0-fold (0.60 log units) between middle value and limit.
By their numbers in this assay, from the lowest: compounds 3, 1 and 2 (each within the scatter of the next, the first and the last beyond it). At a limit, above all of these: compound 4.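

In this assay compound 4 gives > 100000 nM, a limit of the assay and not a number: the limit of > 100000 nM in this assay, at which 1 of the 4 values shown sits.

Among the three amides with a ring of carbon only, exchanging the aryl group on the carbonyl carbon had produced steps no larger than modest, whereas 2,4-dichloropyrimidin-5-yl gives steps that all lie beyond the scatter: an at least 7.4-fold higher number from compound 3 to compound 4 (0.87 log units; beyond the scatter), an at least 2.2-fold higher number from compound 2 to compound 4 (0.34 log units; beyond the scatter) and an at least 3.7-fold higher number from compound 1 to compound 4 (0.57 log units; beyond the scatter). Within the data shown here, this shows that the group at this position, on a carbonyl carbon whose other neighbour is an amide-type nitrogen, can matter more than the earlier compounds suggested, even though 3,5-dimethylphenyl and 2,4-dichloropyrimidin-5-yl have the same count of heavy atoms.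

Ring nitrogen and chlorine enter together in compound 4, so the compounds shown cannot assign the change to either, and a dichlorophenyl group or a pyrimidin-5-yl without chlorine would be needed to separate them. As far as these compounds go, it also remains open how an aryl group carrying an amine or a carboxylic acid would behave at this carbonyl carbon.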